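Methoxy on the benzyl ring of compound 3

This account rests on a few compounds, and the source may have more. Where it says the series, first, only, none or still open, it means among the compounds named here.

Measured so far:
compound 1 `COc1ccc(CNC(=O)c2nc(-c3ccc(F)cc3)n(CC[C@@H](O)C[C@@H](O)CC(=O)O)c2C2CC2)cc1F` — 3.7 nM
compound 2 `COc1cccc(CNC(=O)c2nc(-c3ccc(F)cc3)n(CC[C@@H](O)C[C@@H](O)CC(=O)O)c2C2CC2)c1` — 1.2 nM
compound 3 `O=C(O)C[C@H](O)C[C@H](O)CCn1c(-c2ccc(F)cc2)nc(C(=O)NCc2ccccc2)c1C1CC1` — 1.4 nM

In an assay on microsomes from liver for inhibition of 3-hydroxy-3-methylglutaryl-coenzyme A reductase (Rattus norvegicus), read by scintillation counting, with stated times of 0.5 h and 0.75 h (a lower number here means a stronger inhibitor, a higher number a weaker inhibitor), compound 3 stands second of the three numbers; compound 2 sits nearest, a 1.2-fold higher number from compound 2 to compound 3 (0.07 log units; within the scatter), while compound 1 is furthest, a 2.6-fold lower number from compound 1 to compound 3 (0.42 log units; beyond the scatter). The benzyl substituent is the only varying part of the shared core.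

Compound 4 is `COc1ccccc1CNC(=O)c1nc(-c2ccc(F)cc2)n(CC[C@@H](O)C[C@@H](O)CC(=O)O)c1C1CC1`. Relative to compound 3 the change is methoxy in place of hydrogen on an aromatic carbon.

The step that bears most directly on this is the removal of a methoxy from the benzyl ring, a 1.2-fold higher number from compound 2 to compound 3 (0.07 log units; within the scatter), a step within the scatter. The larger steps in this assay, a 3.1-fold lower number from compound 1 to compound 2 (0.49 log units; beyond the scatter) and a 2.6-fold lower number from compound 1 to compound 3 (0.42 log units; beyond the scatter), involve the 3-fluoro-4-methoxyphenyl group and do not isolate a single methoxy. A methoxy on this ring has so far left the number essentially unchanged, so for compound 4 the expected step is a 1.1-fold higher number from compound 3 to compound 4 (0.06 log units; within the scatter), none beyond the scatter. Compound 4 is estimated at 1.6 nM, within 0.6 nM to 4.5 nM.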

Compound 4, half-maximal inhibitory concentration: 7 nM
For compound 4 the middle estimate is 4.4-fold (0.64 log units) below the measured one; measured number outside the range, above it.
By their numbers in this assay, from the lowest: compounds 2 and 3 (each within the scatter of the next); then compounds 1 and 4 (each within the scatter of the next).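

In this assay, a methoxy on the benzyl ring no longer reads as neutral once it stands ortho to a large group: a 5.0-fold higher number from compound 3 to compound 4 (0.70 log units; beyond the scatter), and moving from the 3-methoxyphenyl group to the 2-methoxyphenyl group gives a 5.8-fold higher number from compound 2 to compound 4 (0.77 log units; beyond the scatter). The same added group therefore gives different results depending on its place on the ring, so the 3-methoxy result does not carry over to the 2-methoxy case. Compound 4 also lands close to the 3-fluoro-4-methoxyphenyl compound, a 1.9-fold higher number from compound 1 to compound 4 (0.28 log units; within the scatter), and nothing available explains the effect of this position.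

Still open, as far as these compounds go, is whether the higher number follows any group at this place or the methoxy alone. A methyl, a hydroxyl, an amine or a longer ethoxy chain there would separate those two readings.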